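A few compounds are considered here, and "the series" means these few. Any claim that something is new, unique, unknown or untested is made for them only; others in the source may bear on it.

Working notes on the series. The shared core of compound 1 `Oc1cc(-c2ccccc2)nc2cc(F)ccc12` carries a free hydroxyl on the ring; in a functional assay on HCT-8 cells (Homo sapiens) for cytotoxicity (on this read-out higher numbers stand for an effect only at larger amounts of compound and lower numbers for an effect already at smaller amounts), compound 1 gives 3.45 ug/mL. Compound 3 `Oc1cc(-c2ccccc2)nc2ccc(Cl)cc12` keeps that hydroxyl, and in this assay compound 3 gives 0.7 ug/mL. Compound 2 `CCCCOc1cc(-c2ccccc2)nc2ccccc12` replaces the hydroxyl with a butyl ether. In this assay compound 2 gives only a limit, > 10 ug/mL, not a number. Compound 2 thus sits at the limit of > 10 ug/mL in this assay, at which 1 of the 3 values shown sits, the weak end of what has been seen so far, while compound 1 and compound 3 each return a number.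

Compound 4 `CCCOc1cc(-c2ccccc2)nc2ccccc12` is not yet measured. It differs from compound 2 by hydrogen in place of methyl on a saturated chain carbon, three bonds along the chain from an oxygen on an aromatic ring. For the measured compounds named here, no pair of measured compounds shows a change of this kind, so the size of the step has to be guessed from the position of compound 2 alone. The shortening of the chain by one carbon is expected to move the read-out in this assay little, if at all, not beyond the usual scatter, and compound 4 is expected to stay near the limit because compound 2 sits at the limit of > 10 ug/mL in this assay, at which 1 of the 3 values shown sits. The expected step is a number no higher from compound 2 to compound 4 (the limit leaves the size open). Compound 4 is estimated at 10 ug/mL, with a range from 4 ug/mL to 25 ug/mL.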

Compound 4, half-maximal effective concentration: > 10 ug/mL
Compound 4 gave a limit, no number (the forecaster's own chance of this, stated with the estimate: 60%); the middle value lies on the limit itself.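

In this assay, for the compounds shown here, compound 2 and compound 4 each give only a limit, not a number, so no step between them can be read. Both sit at the same limit: the limit of > 10 ug/mL in this assay, at which 2 of the 4 values shown sit. The compounds shown leave open how far butyl to propyl moves the read-out, and where either compound would fall on a measured scale.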